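A few compounds are considered here, and "the series" means these few. Any claim that something is new, unique, unknown or untested is made for them only; others in the source may bear on it.

Measured so far:
Compound 1 `COc1cc(NC(C)CCCN2C(=O)CN(C(=O)[C@H](N)CCSC)C2(C)C)c2ncccc2c1`: in an ADME assay on a cell-free system (plasma, Homo sapiens) for metabolic stability, with Plasma (Rattus norvegicus) as the target, read by HPLC (on this read-out higher numbers stand for a longer-lived compound and lower numbers for a shorter-lived compound), compound 1 gives > 3 h, which is a limit of the assay and not a number.
Compound 2 `COc1cc(NC(C)CCCN2C(=O)[C@@H](C)NC2(C)C)c2ncccc2c1`: in this assay compound 2 gives > 3 h, again a limit of the assay.

For the measured compounds named here, compound 2 therefore stands at the limit of the measurement, and so does the only other value in hand (the limit of > 3 h in this assay, at which 2 of the 2 values shown sit); nothing in these two values separates one compound from the other.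

Compound 3 `COc1cc(NC(C)CCCN2C(=O)CNC2(C)C)c2ncccc2c1` has not yet been measured. It differs from compound 2 by hydrogen in place of methyl on a saturated ring carbon. Going by the values given here, no measured pair here carries this change, so no step can be read from the data. Since compound 2 sits at the limit with > 3 h, the expectation is a step of no real size, none beyond the usual scatter, a step that the limit leaves unreadable from compound 2 to compound 3. Compound 3 is accordingly expected to give about 4 h, between 2 h and 8 h, most likely reported again as a limit.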

Compound 3, half-life: > 3 h
Compound 3: only a limit was reported; the forecaster's own chance of this, stated with the estimate: 80%; the middle value does not contradict the limit.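

Compound 3 gives > 3 h in this assay and this is a limit of the assay, not a number. For the compounds shown here, no step from compound 1 or compound 2 to compound 3 can be read: the limit of > 3 h in this assay, at which 3 of the 3 values shown sit. The compounds shown leave open how long each actually lasts, and whether either structural change matters.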